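The source may report more compounds than this note shows. Statements on the series, on what has been measured and on what is new or still open speak of the compounds shown alone.

For the measured compounds named here, compound 2 `O=C1O[C@H]([C@@H](O)Cn2cc(CNS(=O)(=O)c3ccc(Cl)cc3)nn2)C(OCc2ccccc2)=C1OCc1ccccc1` gives 4170 nM in a functional assay on MCF7 cells (Homo sapiens) for antiproliferative activity, read by MTT assay, with a stated time of 72 h (a higher number here means a weaker inhibitor, a lower number a stronger inhibitor), one of only two numbers recorded; the other belongs to compound 1 `CCCCc1cn(C[C@H](O)[C@H]2OC(=O)C(OCc3ccccc3)=C2OCc2ccccc2)nn1`, which gives 7910 nM in this assay, and the step of a 1.9-fold lower number from compound 1 to compound 2 (0.28 log units; within the scatter) lies within the scatter. Compound 3 `Cc1ccc(S(=O)(=O)NCc2cn(C[C@H](O)[C@H]3OC(=O)C(OCc4ccccc4)=C3OCc3ccccc3)nn2)cc1` differs from compound 2 by methyl in place of chloro on an aromatic carbon. Going by the values given here, no measured step touches this position, and the single step known, a 1.9-fold lower number from compound 1 to compound 2 (0.28 log units; within the scatter), is itself within the scatter, so nothing beyond the scatter is expected in this assay; the expected step is a 1.2-fold higher number from compound 2 to compound 3 (0.08 log units; within the scatter). Compound 3 is estimated at 5000 nM, within a range from 2000 nM to 12500 nM.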

Compound 3, half-maximal inhibitory concentration: 6400 nM
Compound 3: the middle estimate sits 1.3-fold (0.11 log units) below what was measured, within the range that was stated.
By their numbers in this assay, from the lowest: compounds 2, 3 and 1 (each within the scatter of the next).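

Methyl in place of chloro on the aromatic carbon para to a large group, the first change read at this position, gives a step (a 1.5-fold higher number from compound 2 to compound 3 (0.19 log units; within the scatter)) in this assay that stays within the scatter. The ((4-methylphenyl)sulfonyl)amino group likewise does not separate from propyl (a 1.2-fold lower number from compound 1 to compound 3 (0.09 log units; within the scatter)), so neither sulfonyl amino compound stands apart from compound 1. No measurement at hand accounts for these readings.

From the compounds shown here alone, whether an amine or a carboxylic acid on this aromatic carbon would move the number beyond the scatter remains open. The same holds for a longer chain in place of propyl.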